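A few compounds are considered here, and "the series" means these few. Any claim that something is new, unique, unknown or untested is made for them only; others in the source may bear on it.

Measured so far in an in vitro functional assay on HEK285-7 cells for antagonist activity at prostaglandin D2 receptor 2 (Homo sapiens), read by BRET and beta-arrestin recruitment; on this read-out higher numbers stand for weaker inhibition and lower numbers for stronger inhibition:
Compound 1 `COc1ccccc1Nc1nc(-c2ccc(F)cc2)c(CC(=O)O)s1` gives 2100 nM.
Compound 2 `O=C(O)Cc1sc(Nc2ccc(Cl)cc2)nc1-c1ccc(F)cc1` gives 1900 nM.
Compound 3 `COc1ccc(-c2nc(-c3ccccc3)c(CC(=O)O)s2)cc1` gives 820 nM.

Compound 2 stands second highest of these three numbers; compound 1 lies within the scatter of it, while compound 3 gives a number beyond the scatter below it. Compound 4 `O=C(O)Cc1sc(Cc2ccccc2Br)nc1-c1ccc(F)cc1` differs from compound 2 in one place: 2-bromobenzyl in place of (4-chlorophenyl)amino on an aromatic carbon. Within the data shown here, the only measured step that touches this position is a 1.1-fold lower number from compound 1 to compound 2 (0.04 log units; within the scatter), which swapped one ring for another on the nitrogen but kept the nitrogen itself. Among the measured compounds shown here, no measured step removes that nitrogen and inserts a benzyl linkage, so the direction is open. Compound 4 is therefore expected to stay close to compound 2, as an estimated step of a 1.3-fold lower number from compound 2 to compound 4 (0.10 log units; within the scatter), with an estimated value of 1500 nM and a range from 400 nM to 6000 nM.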

Compound 4, half-maximal inhibitory concentration: > 100000 nM
Compound 4: a limit, no number; the forecaster's own chance of this, stated with the estimate: 10%; middle value at least 66-fold (1.82 log units) away from the limit.
By their numbers in this assay, from the lowest: compound 3; then compounds 2 and 1 (each within the scatter of the next). At a limit, above all of these: compound 4.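

Replacing (4-chlorophenyl)amino with 2-bromobenzyl on this aromatic carbon gives an at least 52-fold higher number from compound 2 to compound 4 (1.72 log units; beyond the scatter), whereas the earlier change of ring on the nitrogen gave only a 1.1-fold lower number from compound 1 to compound 2 (0.04 log units; within the scatter). So this position does tolerate some change, but not every change: the group attached here can decide whether any inhibition is seen within the measured range. The result for compound 4 is a limit, not a number: the limit of > 100000 nM in this assay, at which 1 of the 4 values shown sits.

This single change removes the nitrogen and also changes the halogen and where it sits, so the compounds shown cannot tell which of these matters. A (2-bromophenyl)amino or a 4-chlorobenzyl group on this carbon would separate them.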